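Swapping the aryl group on a triazole: no signal yet

The source may hold more compounds than are shown below. What is called first, only, known or untested is meant among the compounds shown, and "the series" means these compounds.

Compound 1 `N#CC1=C(N)Oc2c(c3nc4ccccc4nc3c3ccccc23)C12C(=O)N(Cc1cnnn1-c1ccc([N+](=O)[O-])cc1)c1ccccc12` is the starting point. In a functional assay on A549 cells (Homo sapiens) for antiproliferative activity, read by MTT assay, with a stated time of 48 h (on this read-out lower numbers stand for stronger inhibition and higher numbers for weaker inhibition), compound 1 gives only the limit of the assay, > 50000 nM, so no number is known for it. Compound 2 `Cc1ccc(C)c(-n2nncc2CN2C(=O)C3(C(C#N)=C(N)Oc4c3c3nc5ccccc5nc3c3ccccc43)c3ccccc32)c1` carries a 2,5-dimethylphenyl in place of the 4-nitrophenyl on an aromatic nitrogen. Compound 2 likewise stops at the limit, > 50000 nM. The step that the two limits leave unreadable from compound 1 to compound 2 therefore cannot be read, since the limit of > 50000 nM in this assay, at which 2 of the 2 values shown sit, holds both values. The unmeasured compound 3 `N#CC1=C(N)Oc2c(c3nc4ccccc4nc3c3ccccc23)C12C(=O)N(Cc1cnnn1-c1cc(Cl)ccc1Cl)c1ccccc12` differs from compound 1 by 2,5-dichlorophenyl in place of 4-nitrophenyl on an aromatic nitrogen. Within the data shown here, the one measured step that bears on this change is the unreadable one just described, and both measured compounds rest at the limit rather than at a number. Nothing among the values points to a gain in inhibition for compound 3, so the step of a number no higher from compound 1 to compound 3 (the limit leaves the size open) is expected to stay within the scatter. Compound 3 is therefore estimated at 50000 nM, with a range from 20000 nM to 100000 nM, and it is most likely to be reported as a limit again.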

Compound 3, half-maximal inhibitory concentration: > 50000 nM
Compound 3: no number, only a limit; the forecaster's own chance of this, stated with the estimate: 80%; the middle value sits exactly at the limit.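

Compound 3 also gives only a limit, > 50000 nM, in this assay. The steps among compound 1, compound 2 and compound 3 therefore cannot be read, because all three rest at the same point: the limit of > 50000 nM in this assay, at which 3 of the 3 values shown sit.

What stays open is whether the 4-nitrophenyl, 2,5-dimethylphenyl and 2,5-dichlorophenyl groups differ from one another at all, and what real number any of these compounds would give.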